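The compounds below may be only part of what the source reports. "The series", "measured", "known", "first", "only" and "open" are said of these compounds alone.

Of the compounds shown here, three have been measured in an ADME assay on microsomes from liver (Rattus norvegicus) for metabolic stability, using NADPH, with a stated time of 10 min; a higher number here means that more of the compound is left, a lower number that less of the compound is left. In it, compound 1 (`NCCCCN(C[C@H]1Cc2cccnc2CN1)[C@H]1CCCc2cccnc21`) gives 49% and compound 2 (`NCCCCN(C[C@H]1Cc2nccnc2CN1)[C@H]1CCCc2cccnc21`) gives 50%, two values within the usual scatter of each other. Compound 3 (`NC/C=C/CN(C[C@H]1Cc2ncccc2CN1)[C@H]1CCCc2cccnc21`) gives 11%, the lowest of the three and beyond the scatter from both of the others. Compound 4 (`NC(=O)NC/C=C/CN(C[C@H]1Cc2ncccc2CN1)[C@H]1CCCc2cccnc21`) has not yet been measured. It differs from compound 3 in one place: carbamoyl in place of hydrogen on an amine nitrogen, with carbamoyl in place of hydrogen on an amine nitrogen, so that aminomethyl becomes ureidomethyl. Among the compounds with values here, no measured pair differs in only one place, so the data offer no direct precedent for this change. With compound 3 at 11%, there is far more room for the number to rise than to fall, so an increase beyond the scatter is expected in this assay. The expected change is a number 19 percentage points higher from compound 3 to compound 4 (beyond the scatter), although this remains uncertain. For compound 4, the estimated percent remaining is 30%, with an expected range of 12% to 55%.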

Compound 4, percent of the compound remaining: 1%
Estimate against measurement, compound 4: 29 percentage points above; the measured number lies below the stated range.
By their numbers in this assay, from the lowest: compounds 4 and 3 (each within the scatter of the next); then compounds 1 and 2 (each within the scatter of the next).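

In this assay, within the data shown here, the single change from aminomethyl to ureidomethyl, carbamoyl in place of hydrogen on an amine nitrogen, gives a number 10 percentage points lower from compound 3 to compound 4 (within the scatter). Among these compounds, this is the first pair that differs in one place, and it shows that, on this compound, the percent remaining does not distinguish the ureido group from the free amine. Nothing available explains this result.

Among the compounds shown here, the pair covers only one group on this nitrogen, so an acetyl group, a methyl group or a carboxylic acid in place of the amine could still give a different reading. It also leaves open whether carbamoyl on the amine nitrogen of compound 1, whose chain and core both differ from those of compound 3, would give a similar step.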